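Crotonamide in place of acrylamide on the shared core

The source may report more compounds than this note shows. Statements on the series, on what has been measured and on what is new or still open speak of the compounds shown alone.

For the measured compounds named here, compound 1 `C=CC(=O)Nc1cccc(Nc2ncnc(Nc3ccc(C(=O)N4CCCCC4)cc3)n2)c1` is the only member of the series with a single number in a functional assay on Ramos cells (Homo sapiens) for antiproliferative activity, read by CCK-8 assay, with a stated time of 24 h (on this read-out lower numbers stand for stronger inhibition and higher numbers for weaker inhibition), where compound 1 gives 6140 nM. Compound 2 `C=CC(=O)Nc1cccc(Nc2ncnc(Nc3ccc(Oc4ccc(OC)cc4)cc3)n2)c1` reports only a limit of the assay, > 100000 nM. Compound 3 `C=CC(=O)Nc1cccc(Nc2ncnc(Nc3ccc(C(=O)Nc4ccccn4)cc3)n2)c1` carries no result at all, "not determined" (no result reported). Going by the values given here, the single measured step, an at least 16-fold higher number from compound 1 to compound 2 (1.21 log units; beyond the scatter), concerns the substituent on the aromatic carbon and rests on the limit (the limit of > 100000 nM in this assay, at which 1 of the 3 values shown sits).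

Compound 4 `C/C=C/C(=O)Nc1cccc(Nc2ncnc(Nc3ccc(C(=O)N4CCCCC4)cc3)n2)c1` differs from compound 1 at the amide end only: prop-1-en-1-yl in place of vinyl on a carbonyl carbon. Among the compounds with values here, no measured step touches this position; compound 2 and compound 3 both keep the vinylcarbonyl of compound 1 unchanged, so the step from compound 1 to compound 2 offers no guide to the size of a change on the carbonyl carbon. With nothing to compare against, the expectation for compound 4 in this assay is a step from compound 1 to compound 4 of a 1.6-fold higher number from compound 1 to compound 4 (0.21 log units; within the scatter), a mild move toward weaker inhibition that may not clear the scatter. On this basis compound 4 is estimated at 10000 nM, with a plausible range from 3000 nM to 40000 nM.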

Compound 4, half-maximal inhibitory concentration: 13200 nM
Compound 4: the middle estimate sits 1.3-fold (0.12 log units) below what was measured, and the stated range covers the measured number.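

In this assay, for the compounds shown here, the carbonyl carbon now has a measured step of its own, where the earlier compounds kept vinyl throughout and spoke only to the substituent on the aromatic carbon. Prop-1-en-1-yl in place of vinyl gives a 2.1-fold higher number from compound 1 to compound 4 (0.33 log units; beyond the scatter), so this position responds to a change as small as the one from vinyl to prop-1-en-1-yl, and the move is toward weaker inhibition, with compound 1 keeping the lower number of the pair. Nothing measured on these two groups bears on this step, and the result stands as an observation without a stated cause.

The compounds shown leave open how a saturated ethyl group, a longer chain, or a prop-1-en-1-yl chain carrying a dimethylamino group would read on the same carbonyl carbon, so one step gives a direction for a single replacement and no trend across groups at this position. They also leave open whether the step from vinyl to prop-1-en-1-yl keeps its direction and size with a substituent other than the (piperidin-1-yl)carbonyl of compound 1 on the aromatic carbon.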